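Chalcone anilide series: bromo to nitrooxy on the chain

This account rests on a few compounds, and the source may have more. Where it says the series, first, only, none or still open, it means among the compounds named here.

Measured in a functional assay on the whole organism (strain albino) for inhibition, with Rattus norvegicus as the target, read by paw edema, with stated times of 30 min and 2 h, at a dose of 100 mg/kg by the oral route; a higher number here means more inhibition at the dose given (going by the name of the read-out), a lower number less inhibition:
compound 1 `Nc1ccc(C(=O)/C=C/c2ccc(Cl)cc2)cc1` gives 50%
compound 2 `O=C(CBr)Nc1ccc(C(=O)/C=C/c2ccc(Cl)cc2)cc1` gives 52%
compound 3 `CC(Br)C(=O)Nc1ccc(C(=O)/C=C/c2ccc(Cl)cc2)cc1` gives 45%

Compound 3 holds the lowest of the three numbers, but its nearest neighbour is compound 1 and its furthest is compound 2, and both gaps sit within the scatter, so no order among the three can be read. The steps seen so far are all small: a number 2 percentage points higher from compound 1 to compound 2 (within the scatter), a number 5 percentage points lower from compound 1 to compound 3 (within the scatter), and a number 7 percentage points lower from compound 2 to compound 3 (within the scatter).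

Compound 4 `CC(O[N+](=O)[O-])C(=O)Nc1ccc(C(=O)/C=C/c2ccc(Cl)cc2)cc1` differs from compound 3 by nitrooxy in place of bromo on a saturated chain carbon bound to a carbonyl carbon and a saturated chain carbon. Among the compounds with values here, no measured step touches this kind of exchange; the only step at the same place, from compound 2 to compound 3, adds a methyl and stays within the scatter, and the two amide substituents tried so far left the number where compound 1 had it. A step in this assay from compound 3 to compound 4 of a number 2 percentage points higher from compound 3 to compound 4 (within the scatter) is therefore expected, that is none beyond the scatter, in no set direction. Compound 4 is estimated at 47%, with a range from 35% to 59%.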

Compound 4, a percentage reported as inhibition, in the whole organism at one dose (the size of the read-out at that dose, not a potency): 55%
Beside the measured number, compound 4's estimate is 8 percentage points below it; the range from low to high includes it.
By their numbers in this assay, from the lowest: compounds 3, 1, 2 and 4 (each within the scatter of the next).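

In this assay the exchange of bromo for nitrooxy on the saturated chain carbon bound to a carbonyl carbon and a saturated chain carbon gives a number 10 percentage points higher from compound 3 to compound 4 (within the scatter) and so shows no effect that can be separated from the scatter. The wider changes read the same way, with a number 3 percentage points higher from compound 2 to compound 4 (within the scatter) for the exchange on the carbonyl carbon and a number 5 percentage points higher from compound 1 to compound 4 (within the scatter) for the whole group on the nitrogen on an aromatic ring, so compound 4 cannot be told apart from compound 1, compound 2 or compound 3 at this dose. No measured evidence here bears on the result.

From the compounds shown here alone, whether an amine, a hydroxy group or a carboxylic acid in place of nitrooxy, or a longer chain carrying it, would move the number beyond the scatter stays open. A single oral dose also leaves open whether these compounds would separate at other doses.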